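Swapping Phenyl for Cyclohexyl and Cell Toxicity

The source may report more compounds than this note shows. Statements on the series, on what has been measured and on what is new or still open speak of the compounds shown alone.

Compound 2 `C[C@H](NC(=O)C(c1cccnc1)N(C(=O)c1ccno1)c1ccc(-c2ccccc2)cc1)c1ccccc1` was tested in a toxicity assay on Vero C1008 cells (Chlorocebus sabaeus) for cytotoxicity, read by neutral red uptake, with a stated time of 5 days; on this read-out lower numbers stand for higher toxicity in this test and higher numbers for lower toxicity in this test. In this assay compound 2 returned only a limit, > 200000 nM, so no number is known for it. That limit, (the limit of > 200000 nM in this assay, at which 1 of the 2 values shown sits), is where compound 2 stands. Compound 1 `C[C@H](NC(=O)C(c1cccnc1)N(C(=O)c1ccco1)c1ccc(C2CCCCC2)cc1)c1ccccc1` also carries cyclohexyl but differs from compound 2 in several places. In this assay compound 1 gives 9610 nM. Compound 3 `C[C@H](NC(=O)C(c1cccnc1)N(C(=O)c1ccno1)c1ccc(C2CCCCC2)cc1)c1ccccc1` is not yet measured; it differs from compound 2 by one change (cyclohexyl in place of phenyl on an aromatic carbon). Within the data shown here, compound 1 and compound 2 are not joined by a single step, so their two values show only that the cyclohexyl-bearing compound gave a number while compound 2 gave a limit. The step from compound 2 to compound 3 is expected to move toward higher toxicity, roughly an at least 6.6-fold lower number from compound 2 to compound 3 (0.82 log units; beyond the scatter), though compound 3 could also stay at the limit. Compound 3 is expected near 30000 nM, within 8000 nM to 200000 nM.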

Compound 3, half-maximal cytotoxic concentration: 17500 nM
Compound 3: the middle estimate sits 1.7-fold (0.23 log units) above what was measured; the range from low to high includes it.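

In this assay, this single change on an aromatic carbon, para to a large group, gives an at least 11-fold lower number from compound 2 to compound 3 (1.05 log units; beyond the scatter), so replacing 4-phenylphenyl with 4-cyclohexylphenyl alone is enough to move the read-out toward higher toxicity in this test. Compound 2 has only a limit, so this step has a minimum size but no exact one: the limit of > 200000 nM in this assay, at which 1 of the 3 values shown sits. The second step, a 1.8-fold higher number from compound 1 to compound 3 (0.26 log units; within the scatter), lies within the scatter, so with 4-cyclohexylphenyl in place, 1,2-oxazol-5-yl and furan-2-yl on the carbonyl carbon cannot be told apart in this test.

The compounds shown leave open how a piperidine ring or an open hexyl chain would read at this position. They also leave open whether furan-2-yl and 1,2-oxazol-5-yl would still read alike alongside 4-phenylphenyl.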